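Formyl to acetyl on the side chain of compound 2

This account rests on a few compounds, and the source may have more. Where it says the series, first, only, none or still open, it means among the compounds named here.

In a functional assay on NCI-H460 cells (Homo sapiens) (on this read-out lower numbers stand for an effect already at smaller amounts and higher numbers for an effect only at larger amounts of compound), compound 1 `CCOC(=O)C(=O)N1N=C(c2ccc(N(C)C)cc2)OC1c1cc(OC)c(OC)c(OC)c1` gives 33 uM, and compound 2 `COc1cc(C2OC(c3ccc(N(C)C)cc3)=NN2C(=O)CNC=O)cc(OC)c1OC` gives 0.04 uM. Among the measured compounds shown here, compound 2 therefore holds the lower of the only two numbers. For the measured compounds named here, the single measured step, an 830-fold lower number from compound 1 to compound 2 (2.92 log units; beyond the scatter), is large and beyond the scatter. It comes with (formylamino)methyl in place of ethoxycarbonyl on a carbonyl carbon.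

Compound 3 `COc1cc(C2OC(c3ccc(N(C)C)cc3)=NN2C(=O)CNC(C)=O)cc(OC)c1OC` is still unmeasured. Its difference from compound 2 is methyl in place of hydrogen on a carbonyl carbon, which turns (formylamino)methyl into acetamidomethyl. Step an 830-fold lower number from compound 1 to compound 2 (2.92 log units; beyond the scatter) bears on this only in part: it introduced the group now being altered, but it replaced far more than a hydrogen. Going by the values given here, its size should not carry over, and no measured step isolates this change. A small move to a higher number in this assay is expected, possibly no larger than the scatter, starting from compound 2 at 0.04 uM. The expected step is a 2.0-fold higher number from compound 2 to compound 3 (0.30 log units; within the scatter). For compound 3 the estimated value is 0.08 uM, with an expected range of 0.015 uM to 0.5 uM.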

Compound 3, concentration for half-maximal effect: 0.48 uM
For compound 3 the middle estimate is 6.0-fold (0.78 log units) below the measured one; measured number inside the range.
By their numbers in this assay, from the lowest: compound 2; then compound 3; then compound 1.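

In this assay, the end of the side chain proves sensitive to very small edits: methyl in place of hydrogen on a carbonyl carbon, which adds only 1 heavy atom and turns formylamino into acetamido, gives a 12-fold higher number from compound 2 to compound 3 (1.08 log units; beyond the scatter). The formyl hydrogen therefore matters in this series, and the read-out at this position separates two closely related groups that share the same amide-type nitrogen and the same core. Acetamidomethyl still keeps a large part of the gain over ethoxycarbonyl, with a 69-fold lower number from compound 1 to compound 3 (1.84 log units; beyond the scatter), so the gain is not exclusive to (formylamino)methyl, although the acetyl compound falls clearly short of the formyl one; no measurement at hand accounts for the size of either step.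

Formyl to acetyl is a single pair, so it cannot yet be said whether the number keeps rising with a longer acyl chain such as propanoyl or with a benzoyl group on the same nitrogen. As far as these compounds go, it is equally open how a free amine or a carboxylic acid at the end of the side chain would read in this assay, and whether the amide-type nitrogen is needed at all.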